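Swapping the Aryl Substituent: Trifluoroacetyl for Trifluoromethoxy

A few compounds are considered here, and "the series" means these few. Any claim that something is new, unique, unknown or untested is made for them only; others in the source may bear on it.

Compound 1 `CN(C)CC[C@H](CSc1ccccc1)Nc1ccc(S(=O)(=O)NC(=O)c2ccc(N3CCN(Cc4ccccc4-c4ccc(Cl)cc4)CC3)cc2)cc1C(F)(F)F`: 3690 ng.h/mL
Compound 2 `Cc1cc(S(=O)(=O)NC(=O)c2ccc(N3CCN(Cc4ccccc4-c4ccc(Cl)cc4)CC3)cc2)ccc1N[C@H](CCN(C)C)CSc1ccccc1`: "not determined" (no result reported)
Compound 3 `CN(C)CC[C@H](CSc1ccccc1)Nc1ccc(S(=O)(=O)NC(=O)c2ccc(N3CCN(Cc4ccccc4-c4ccc(Cl)cc4)CC3)cc2)cc1OC(F)(F)F`: "not determined" (no result reported)

Three close analogues share the same core and have been run in an ADME assay on the whole organism (plasma, strain Sprague-Dawley) for pharmacokinetics, with Rattus norvegicus as the target, at a dose of 5 mg/kg by the oral route; on this read-out higher numbers stand for higher exposure at the dose given and lower numbers for lower exposure. For the measured compounds named here, compound 1 is the only one with a number, and in this assay compound 1 gives 3690 ng.h/mL. For compound 2 the outcome in this assay is "not determined" (no result reported), and for compound 3 the outcome in this assay is likewise "not determined" (no result reported), so compound 3 stands without a number of its own, and nothing can be said about how it compares with compound 1.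

Compound 4 `CN(C)CC[C@H](CSc1ccccc1)Nc1ccc(S(=O)(=O)NC(=O)c2ccc(N3CCN(Cc4ccccc4-c4ccc(Cl)cc4)CC3)cc2)cc1C(=O)C(F)(F)F` is the next analogue and has not been measured. It differs from compound 3 in one place: (trifluoromethyl)carbonyl in place of trifluoromethoxy on an aromatic carbon. Going by the values given here, since compound 3 has no value in this assay, no step can be computed, and no direction or size can be asserted for this change; the only anchor is compound 1. On that basis the exposure of compound 4 in this assay is expected to be around 2000 ng.h/mL, with a plausible range from 400 ng.h/mL to 8000 ng.h/mL.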

Compound 4, area under the concentration-time curve: 1080 ng.h/mL
For compound 4 the middle estimate is 1.9-fold (0.27 log units) above the measured one, and the stated range covers the measured number.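

In this assay, for the compounds shown here, (trifluoromethyl)carbonyl in place of trifluoromethyl on this aromatic carbon gives a 3.4-fold lower number from compound 1 to compound 4 (0.53 log units; beyond the scatter), the only step that can be read at this position, and it shows that exposure responds to the group placed there. The steps involving compound 2 and compound 3 cannot be read, so this single change carries all that is known, and the trifluoromethoxy-to-(trifluoromethyl)carbonyl swap itself stays without a size or direction. No measurement shown accounts for the lower number.

Going by these compounds, how the methyl of compound 2 and the trifluoromethoxy of compound 3 rank against the two groups with numbers remains open. So does what a nitrile, a chlorine or a carboxylic acid on this same aromatic carbon would do to exposure, as two values establish no trend.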